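The source may hold more compounds than are shown below. What is called first, only, known or untested is meant among the compounds shown, and "the series" means these compounds.

In a physicochemical assay for solubility, in phosphate buffer, with a stated time of 18 h, at pH 7.4 (on this read-out lower numbers stand for lower solubility and higher numbers for higher solubility), compound 1 `COc1cc2ncnc(-n3nc(-c4ccccn4)nc3N)c2cc1OCCCN(C)C` gives 53000 nM and compound 2 `COc1cc2ncnc(-n3nc(-c4ccccn4)nc3N)c2cc1OCCCCNC(=O)OC(C)(C)C` gives 500 nM, the lower of the two numbers. Compound 3 `COc1cc2ncnc(-n3nc(-c4ccccn4)nc3N)c2cc1OCCNC(=O)OC(C)(C)C` differs from compound 2 at one place: (tert-butoxycarbonyl)amino in place of 2-((tert-butoxycarbonyl)amino)ethyl on a saturated chain carbon, two bonds along the chain from an oxygen on an aromatic ring. (Tert-butoxycarbonyl)amino is kept at the end of the chain in both compounds. Among the compounds with values here, the only measured step, a 110-fold lower number from compound 1 to compound 2 (2.03 log units; beyond the scatter), was large, but it exchanged dimethylamino for ((tert-butoxycarbonyl)amino)methyl, and no measured step isolates the present change. The expected result is no change beyond the scatter, with no firm direction, in this assay: a 1.2-fold higher number from compound 2 to compound 3 (0.08 log units; within the scatter). Compound 3 is estimated at 600 nM, within an expected range of 170 nM to 2500 nM.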

Compound 3, solubility: 2000 nM
Estimate against measurement, compound 3: 3.3-fold (0.52 log units) below, and the stated range covers the measured number.
By their numbers in this assay, from the lowest: compound 2; then compound 3; then compound 1.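

In this assay, the carbamate end group held constant, the change from 2-((tert-butoxycarbonyl)amino)ethyl to (tert-butoxycarbonyl)amino at this saturated chain carbon gives a 4.0-fold higher number from compound 2 to compound 3 (0.60 log units; beyond the scatter), so chain length alone moves the number here. Set against the dimethylamino chain, the (tert-butoxycarbonyl)amino chain still shows a 27-fold lower number from compound 1 to compound 3 (1.42 log units; beyond the scatter), so the shorter chain closes only part of the gap. Nothing shown accounts for either step. As far as these compounds go, whether a still shorter chain would continue the rise stays open. So does how a free primary amine or a carboxylic acid at the chain end would compare.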